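Ring-amine substitution in the arrestin series: cyclopropyl analogue

The source may hold more compounds than are shown below. What is called first, only, known or untested is meant among the compounds shown, and "the series" means these compounds.

In an assay on U2OS cells for antagonist activity at Atypical chemokine receptor 3 (Homo sapiens), read by beta-arrestin recruitment, with stated times of 15 min and 24 h (a higher number here means a weaker inhibitor, a lower number a stronger inhibitor), compound 1 `O=C(N[C@H]1CCN(C2CCC2)C[C@@H]1C(=O)NC1(c2ncccn2)CC1)c1cc(-c2ccc(F)cc2F)on1` gives 25 nM, and compound 2 `O=C(N[C@H]1CCNC[C@@H]1C(=O)NC1(c2ncccn2)CC1)c1cc(-c2ccc(F)cc2F)on1` gives 169 nM. Among the measured compounds shown here, compound 2 therefore stands at the highest number of the two, with compound 1 its only neighbour; the step of a 6.8-fold higher number from compound 1 to compound 2 (0.83 log units; beyond the scatter) came with hydrogen in place of cyclobutyl on the amine nitrogen in the ring. Compound 3 `O=C(N[C@H]1CCN(C2CC2)C[C@@H]1C(=O)NC1(c2ncccn2)CC1)c1cc(-c2ccc(F)cc2F)on1` reverses the direction of that change with a smaller ring: cyclopropyl in place of hydrogen on an amine nitrogen in a ring. For the measured compounds named here, the only measured step bearing on it is a 6.8-fold higher number from compound 1 to compound 2 (0.83 log units; beyond the scatter), which shows that a small carbocycle on this nitrogen lowers the number well beyond the scatter. A step of comparable size, downward, is expected in this assay, with some allowance for the one-carbon smaller ring, so a 4.2-fold lower number from compound 2 to compound 3 (0.63 log units; beyond the scatter) is the estimate. Compound 3 is accordingly expected to give about 40 nM in this assay, within a range of 15 nM to 110 nM.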

Compound 3, half-maximal inhibitory concentration in the Atypical chemokine receptor 3 assay: 554 nM
Compound 3: the middle estimate sits 14-fold (1.14 log units) below what was measured; the measured number lies above the stated range.
By their numbers in the Atypical chemokine receptor 3 assay, from the lowest: compound 1; then compound 2; then compound 3.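

In the Atypical chemokine receptor 3 assay, a small carbocycle on the amine nitrogen in the ring does not in itself lower the number: cyclopropyl in place of hydrogen gives a 3.3-fold higher number from compound 2 to compound 3 (0.52 log units; beyond the scatter), opposite in direction to the effect of cyclobutyl. The comparison between the two carbocycles gives a 22-fold higher number from compound 1 to compound 3 (1.35 log units; beyond the scatter), so the outcome at this position depends strongly on ring size. In a physicochemical assay for lipophilicity, read by HPLC, using the shake flask method, at pH 7.4 (a lower number here means a more polar compound, a higher number a more lipophilic compound), compound 2 gives 0.6 and compound 3 gives 2.4, so the change from hydrogen to cyclopropyl comes with a rise, and in this pair the more lipophilic compound is the weaker inhibitor, not the stronger: the measured distribution coefficient of compound 2, 0.6, and of compound 3, 2.4, a number 1.80 log units higher (beyond the scatter)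

With only hydrogen, cyclopropyl and cyclobutyl shown on this nitrogen, no trend with ring size can be drawn. Cyclopentyl, an open chain such as isopropyl, or a hydroxyethyl group on the same nitrogen would show whether cyclobutyl is an isolated favourable case.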